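Moving the methyl on the aryl of compound 1

The source may hold more compounds than are shown below. What is called first, only, known or untested is meant among the compounds shown, and "the series" means these compounds.

Compound 1 `CC(=O)N1N=C(c2ccc(O)cc2O)CC1c1cccc(C)c1` gives 50 nM in an assay on mitochondria for inhibition of Monoamine oxidase (Bos taurus) (a higher number here means a weaker inhibitor, a lower number a stronger inhibitor), the lowest of the three numbers in hand. Compound 2 `CC(=O)N1N=C(c2ccccc2O)CC1c1cccc(C)c1` gives 5500 nM in this assay, and compound 3 `CC(=O)N1N=C(c2ccccc2)CC1c1ccc(Cl)cc1` gives 6000 nM in this assay; both stand far apart from compound 1. Among the measured compounds shown here, the only single-point step known, a 110-fold higher number from compound 1 to compound 2 (2.04 log units; beyond the scatter), concerns the hydroxy group alone. Compound 3 differs from compound 1 in more than one place, so its value cannot be tied to any one change.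

Compound 4 `CC(=O)N1N=C(c2ccc(O)cc2O)CC1c1ccccc1C` differs from compound 1 by 2-methylphenyl in place of 3-methylphenyl on a saturated ring carbon. For the measured compounds named here, no measured pair shows this change or any other rearrangement of the methylphenyl group, so nothing in hand bears on it directly; the dihydroxyphenyl part that separates compound 1 from compound 2 is retained unchanged. On that basis the step expected in this assay, a 1.2-fold higher number from compound 1 to compound 4 (0.08 log units; within the scatter), is none beyond the scatter. Compound 4 is therefore estimated at 60 nM in this assay, with a range from 20 nM to 200 nM.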

Compound 4, inhibition constant: 80 nM
Compound 4: middle estimate off by 1.3-fold (0.12 log units), on the low side, within the range that was stated.
By their numbers in this assay, from the lowest: compounds 1 and 4 (each within the scatter of the next); then compounds 2 and 3 (each within the scatter of the next).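

In this assay, 2-methylphenyl in place of 3-methylphenyl on the saturated ring carbon gives a 1.6-fold higher number from compound 1 to compound 4 (0.20 log units; within the scatter), so moving the methyl between these two places on the aryl leaves the number within the scatter. Among the compounds shown here, this is the first single-place reading at this ring carbon, and it contrasts with the only earlier step, a 110-fold higher number from compound 1 to compound 2 (2.04 log units; beyond the scatter), which concerns the hydroxy group and lies beyond the scatter. No measurement on these groups accompanies the result, so it stands as an observation without an explanation.

Still open, on these data alone, is whether the same step holds on the core of compound 2, which has one hydroxy group fewer. Also open, as far as these compounds go, is how the number responds when an amine, a carboxylic acid or a longer chain takes the place of the methyl on the aryl.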